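The compounds below may be only part of what the source reports. "The series", "measured", "known", "first", "only" and "open" are said of these compounds alone.

Going by the values given here, compound 2 `CNC(=O)c1cccn(Cc2ccccc2)c1=O` is the only compound with a plain number in a physicochemical assay for solubility (on this read-out higher numbers stand for higher solubility and lower numbers for lower solubility), where compound 2 gives 78 ug/mL. Compound 1 `CCNC(=O)c1cc(C(=O)NC)c(=O)n(Cc2ccccc2)c1` carries an extra ethylcarbamoyl group. In this assay compound 1 gives >= 144 ug/mL, which is a limit of the assay and not a number. Among the compounds with values here, the only measured step is an at least 1.8-fold lower number from compound 1 to compound 2 (0.26 log units; that floor lies within the scatter). Compound 3 `CNC(=O)c1cc(C(=O)NCC(C)C)cn(Cc2ccccc2)c1=O` shows (isobutylcarbamoyl in place of hydrogen on an aromatic carbon), a change of the same kind as that step but in the opposite direction, so a rise of at least similar size is expected, possibly still within the scatter. Compound 3 is estimated at 120 ug/mL, between 55 ug/mL and 260 ug/mL, an expected step of a 1.5-fold higher number from compound 2 to compound 3 (0.19 log units; within the scatter).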

Compound 3, solubility: 43 ug/mL
Estimate against measurement, compound 3: 2.8-fold (0.45 log units) above; the measured number lies below the stated range.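

In this assay, isobutylcarbamoyl at this ring carbon shows no clear difference from hydrogen (a 1.8-fold lower number from compound 2 to compound 3 (0.26 log units; within the scatter)). The side chain on this amide does count, since isopropyl in place of methyl on the chain carbon bound to the amide nitrogen gives a clear drop (an at least 3.3-fold lower number from compound 1 to compound 3 (0.52 log units; beyond the scatter)). Compound 1 stands at a limit of the assay and not at a number, so that step is only a floor: the limit of >= 144 ug/mL in this assay, at which 1 of the 3 values shown sits.

On these data alone, whether an amine or a carboxylic acid on this chain would shift the number stays open. As far as these compounds go, the true distance between compound 1 and the other two compounds also stays open.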